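This account rests on a few compounds, and the source may have more. Where it says the series, first, only, none or still open, it means among the compounds named here.

Series notes. For the measured compounds named here, in a physicochemical assay for solubility, in phosphate buffer (on this read-out lower numbers stand for lower solubility and higher numbers for higher solubility), compound 2 `CCOC(=O)c1ccc(Nc2ccnc(-c3cccnc3)n2)cc1` gives 61000 nM, the highest of the two numbers measured so far. Going by the values given here, compound 1 `CCOC(=O)c1ccc(Nc2cc(C)nc(-c3ccncc3)n2)cc1` gives 4000 nM in this assay, a gap beyond the scatter, though the two structures differ in more than one place, so no single step can be drawn from them. Compound 3 `CCOC(=O)c1ccc(Nc2cc(C)nc(-c3cccnc3)n2)cc1` follows compound 2 by one change: methyl in place of hydrogen on an aromatic carbon. For compound 3 a moderate fall in this assay is expected, a 3.1-fold lower number from compound 2 to compound 3 (0.48 log units; beyond the scatter). Among the compounds with values here, the only pointer is compound 1, which carries a methyl and gives 4000 nM. Compound 3 is estimated at 20000 nM, range 6000 nM to 60000 nM.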

Compound 3, solubility: 71000 nM
Compound 3: middle estimate off by 3.6-fold (0.55 log units), on the low side, outside the stated range (above it).
By their numbers in this assay, from the lowest: compound 1; then compounds 2 and 3 (each within the scatter of the next).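

In this assay methyl in place of hydrogen on this aromatic carbon, next to the ring nitrogen, gives a 1.2-fold higher number from compound 2 to compound 3 (0.07 log units; within the scatter) and so leaves no step beyond the scatter with the pyridin-3-yl group present. With the methyl held constant, pyridin-3-yl in place of pyridin-4-yl gives an 18-fold higher number from compound 1 to compound 3 (1.25 log units; beyond the scatter) as the large step in this set. Nothing measured here accounts for either step. From the compounds shown here alone, it remains open whether methyl in place of hydrogen reads the same with pyridin-4-yl present. Also open, going by these compounds, is whether a methoxy group or an amine on this carbon would match methyl.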